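Cytotoxicity in the aryl thioether series: working notes

This account rests on a few compounds, and the source may have more. Where it says the series, first, only, none or still open, it means among the compounds named here.

Measured so far in an ADME assay on HepG2 2.2.15 cells (Homo sapiens) for cytotoxicity, read by MTT assay, with a stated time of 9 days; a higher number here means that more compound is tolerated, a lower number that less compound is tolerated:
compound 1 `CCOC(=O)c1cc2c(Cn3ccnc3)c(O)c(OC)cc2nc1C[S+]([O-])c1cccc(OC)c1` gives 194 uM
compound 2 `CCOC(=O)c1cc2c(Cn3ccnc3)c(O)c(OC)cc2nc1CSc1ccc(F)cc1` gives 202 uM
compound 3 `CCOC(=O)c1cc2c(CN3CCCC3)c(O)c(OC)cc2nc1CSc1ccc(F)cc1` gives 47.3 uM

Compound 2 gives the highest of the three numbers in this assay; compound 1 sits within the scatter of it, while compound 3 is the furthest away, the step of a 4.3-fold lower number from compound 2 to compound 3 (0.63 log units; beyond the scatter) being a modest one. Compound 4 `CCOC(=O)c1cc2c(Cn3ccnc3)c(O)c(OC)cc2nc1CSc1cccc(OC)c1` has not yet been measured. It differs from compound 2 in one place: 3-methoxyphenyl in place of 4-fluorophenyl on a sulfur. Going by the values given here, the only measured step that touches this part of the molecule is a 1.0-fold higher number from compound 1 to compound 2 (0.02 log units; within the scatter), which altered the group on the same sulfur without moving the number beyond the scatter. Compound 1 already carries the 3-methoxyphenyl group that enters in compound 4, and its value lies within the scatter of compound 2. The change from compound 2 to compound 4 is therefore expected to produce no step beyond the scatter in this assay, that is a 1.1-fold lower number from compound 2 to compound 4 (0.03 log units; within the scatter). Compound 4 is estimated at 190 uM in this assay, with a range from 100 uM to 350 uM.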

Compound 4, half-maximal toxic concentration: 187 uM
Beside the measured number, compound 4's estimate is 1.0-fold (0.01 log units) above it; low and high end bracket the measured number.
By their numbers in this assay, from the lowest: compound 3; then compounds 4, 1 and 2 (each within the scatter of the next).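

In this assay, 3-methoxyphenyl in place of 4-fluorophenyl on a sulfur gives a 1.1-fold lower number from compound 2 to compound 4 (0.03 log units; within the scatter) and so, with the sulfur otherwise unchanged, this aryl change alone stays within the scatter. The step between compound 1 and compound 2 changed the aryl group and the oxygen on the sulfur together, whereas a 1.0-fold lower number from compound 1 to compound 4 (0.02 log units; within the scatter) holds 3-methoxyphenyl constant and shows that removing that oxygen also stays within the scatter. Nothing available explains why these changes leave the number within the scatter.

On these data alone, it remains open whether an amine or a carboxylic acid on the phenyl ring, or a longer chain in place of the saturated chain carbon, would keep the number within the scatter. Also open, as far as these compounds go, is whether 3-methoxyphenyl would behave the same way with pyrrolidin-1-yl in place of 1H-imidazol-1-yl, the change that gives a 4.3-fold lower number from compound 2 to compound 3 (0.63 log units; beyond the scatter).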